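A Trifluoromethoxy Addition Tested on a Second Core

The source may report more compounds than this note shows. Statements on the series, on what has been measured and on what is new or still open speak of the compounds shown alone.

Compound 2 `CC(c1ccc(-c2ccccc2)c(F)c1)c1nnc2n1N=C(c1ccccc1)CS2` and compound 1 `CC(c1ccc(-c2ccccc2)c(F)c1)c1nnc2n1N=C(c1ccc(OC(F)(F)F)cc1)CS2` share one core, while compound 3 `CC(C)Cc1ccc(C(C)c2nnc3n2N=C(c2ccccc2)CS3)cc1` and compound 4 `CC(C)Cc1ccc(C(C)c2nnc3n2N=C(c2ccc(OC(F)(F)F)cc2)CS3)cc1` share another. The difference between the two cores is not broken down here. In a functional assay on HCT-116 cells (Homo sapiens) for inhibition, read by sulforhodamine B assay, with a stated time of 72 h (a lower number here means a stronger inhibitor, a higher number a weaker inhibitor), compound 2 gives 9700 nM, and compound 1 gives 5400 nM. The change from compound 2 to compound 1 is trifluoromethoxy in place of hydrogen on an aromatic carbon, and it made a 1.8-fold lower number from compound 2 to compound 1 (0.25 log units; within the scatter). In this assay compound 3 gives 7600 nM, a number that lies within the scatter of both compound 2 and compound 1. Compound 4 has not yet been measured. It differs from compound 3 by trifluoromethoxy in place of hydrogen on an aromatic carbon, the same change that turned compound 2 into compound 1, here made on the second core. Going by the values given here, only one measured example of this change exists, so the expectation rests on that single step. The expected step is a 1.7-fold lower number from compound 3 to compound 4 (0.23 log units; within the scatter), because on the other core the same change gave a 1.8-fold lower number from compound 2 to compound 1 (0.25 log units; within the scatter). In this assay compound 4 is therefore estimated at 4500 nM, with a likely range from 1500 nM to 12000 nM.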

Compound 4, half-maximal inhibitory concentration: 3000 nM
Compound 4: middle estimate off by 1.5-fold (0.18 log units), on the high side; the range from low to high includes it.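

In this assay, the new step is a 2.5-fold lower number from compound 3 to compound 4 (0.40 log units; beyond the scatter), a modest one that lies beyond the usual scatter. Set beside the earlier step on the other core, the two results agree, so in this series the trifluoromethoxy change carried over from one core to the other with no detectable difference in size: the same change on two cores in this assay, a 1.8-fold lower number (0.25 log units; within the scatter) from compound 2 to compound 1 and a 2.5-fold lower number (0.40 log units; beyond the scatter) from compound 3 to compound 4, 1.4-fold (0.15 log units) apart, within the scatter of two such steps This rests on just two pairs of compounds, one of whose steps lies within the scatter, so it does not show that the change would act alike on any further core, and it does not explain why the number moves.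

The compounds shown carry only hydrogen or trifluoromethoxy at this place on the ring, para to a large group. Going by these compounds, it remains open how a methoxy group, a chlorine atom, an amine or a carboxylic acid at that place would compare in this assay.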